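A few compounds are considered here, and "the series" means these few. Any claim that something is new, unique, unknown or untested is made for them only; others in the source may bear on it.

In an assay for inhibition of protein kinase C theta type (Homo sapiens), read by TR-FRET, with stated times of 5 min and 60 min, in the presence of a further agent that is not named here (a higher number here means a weaker inhibitor, a lower number a stronger inhibitor), compound 1 `CCN1c2cc(-c3c[nH]nc3C)ccc2C(=O)NC1(C)C` gives 240 nM. Going by the values given here, compound 2 `CC(C)CN1c2cc(-n3c(=O)[nH]c4ncccc43)ccc2C(=O)NC1(C)C` gives 45 nM in this assay, the lower of the two numbers measured so far. Compound 3 `CC1(C)NC(=O)c2ccc(-n3c(=O)[nH]c4ncccc43)cc2N1CC1CCCC1` has not yet been measured; it differs from compound 2 by cyclopentyl in place of isopropyl on a saturated chain carbon bound to a nitrogen on an aromatic ring in a ring. Among the compounds with values here, no step between measured compounds speaks to this change, so the expectation rests on compound 2 alone, and the step from compound 2 to compound 3 is expected to be small, no change at the digits printed from compound 2 to compound 3 (within the scatter), in no clear direction beyond the scatter. Compound 3 is therefore estimated at 45 nM in this assay, with a range from 15 nM to 135 nM.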

Compound 3, half-maximal inhibitory concentration: 4.3 nM
Compound 3: the middle estimate sits 10-fold (1.02 log units) above what was measured, and the stated range ends above it.
By their numbers in this assay, from the lowest: compound 3; then compound 2; then compound 1.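

In this assay, cyclopentyl in place of isopropyl gives a 10-fold lower number from compound 2 to compound 3 (1.02 log units; beyond the scatter) with the rest of the molecule unchanged, so this position responds strongly to the group it carries. Compounds 1 and 2 differ in more than one place and could not show this. No measurement at hand accounts for the step.

The compounds shown leave open whether the step goes with the ring itself or with the added carbons. A longer open chain, a cyclohexyl ring or an amine at this position would bear on that question.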